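Chalcone series: trimethoxyphenyl in place of methoxyphenyl

This account rests on a few compounds, and the source may have more. Where it says the series, first, only, none or still open, it means among the compounds named here.

Compound 1 `COc1cc(/C=C/C(=O)c2cccc(-n3cc(-c4ccccc4)[nH]c3=O)c2)cc(OC)c1OC` carries a plain phenyl on the five-membered ring; in a functional assay on RPMI8266 cells (Homo sapiens) for inhibition (on this read-out higher numbers stand for weaker inhibition of growth and lower numbers for stronger inhibition of growth), compound 1 gives 620 nM. Compound 2 `COc1ccc(-c2cn(-c3cccc(C(=O)/C=C/c4cc(OC)c(OC)c(OC)c4)c3)c(=O)[nH]2)cc1` carries a 4-methoxyphenyl there and in this assay compound 2 gives 920 nM. Of the two measured numbers, that of compound 2 is not set apart from that of compound 1 beyond the scatter: the step of a 1.5-fold higher number from compound 1 to compound 2 (0.17 log units; within the scatter). Compound 3 `COc1cc(/C=C/C(=O)c2cccc(-n3cc(-c4cc(OC)c(OC)c(OC)c4)[nH]c3=O)c2)cc(OC)c1OC` differs from compound 2 by 3,4,5-trimethoxyphenyl in place of 4-methoxyphenyl on an aromatic carbon. For the measured compounds named here, only one measured step bears on this change, the one from compound 1 to compound 2, and it is within the scatter; the further methoxy groups on the same ring are therefore expected to leave this assay essentially unchanged, with the step of a 1.1-fold higher number from compound 2 to compound 3 (0.04 log units; within the scatter). For compound 3 the value in this assay is estimated at 1000 nM, within a range of 400 nM to 2800 nM.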

Compound 3, concentration for 50% growth inhibition: 230 nM
Estimate against measurement, compound 3: 4.3-fold (0.64 log units) above; the whole stated range lies above it.
By their numbers in this assay, from the lowest: compound 3; then compounds 1 and 2 (each within the scatter of the next).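

For the compounds shown here, on an aromatic carbon of the five-membered aromatic ring, 3,4,5-trimethoxyphenyl gives the first change beyond the scatter at this position in this assay: a 4.0-fold lower number from compound 2 to compound 3 (0.60 log units; beyond the scatter) and a 2.7-fold lower number from compound 1 to compound 3 (0.43 log units; beyond the scatter), both modest. A 4-methoxyphenyl group had not separated compound 2 from compound 1, so this position does respond to the aryl group it carries, and compound 3 stands as the most potent of the three, its steps to both others lying beyond the scatter. No evidence is at hand that explains why the 3,4,5-trimethoxyphenyl group differs from the 4-methoxyphenyl group here.

Whether all three methoxy groups are needed for this step remains open, since the compounds shown pass from one methoxy to three with nothing in between. Also open, going by these compounds, is how a hydroxyl, an amine or a carboxylic acid on this phenyl ring would read in this assay.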